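From compound 2 to compound 4 at the limit

The source may hold more compounds than are shown below. What is called first, only, known or untested is meant among the compounds shown, and "the series" means these compounds.

In an ADME assay on BJ cells (Homo sapiens) for cytotoxicity, with a stated time of 72 h (on this read-out lower numbers stand for an effect already at smaller amounts and higher numbers for an effect only at larger amounts of compound), the measured compounds stand as follows:
Compound 1 `C=C[C@@](C)(/C=C/c1ccc(O)c(/C=C/C#N)c1)CCC=C(C)C` gives > 36600 nM as a limit
Compound 2 `C=C[C@@](C)(/C=C/c1ccc(O)c(/C=C/C(=O)OCC)c1)CCC=C(C)C` gives > 36600 nM as a limit
Compound 3 `C=C[C@@](C)(/C=C/c1ccc(O)c(/C=C/c2ccc(Cl)cc2)c1)CCC=C(C)C` gives > 36600 nM as a limit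

Compound 2 has no number in this assay and stands only at > 36600 nM as a limit. Its two companions offer no number either, and the whole series sits at the limit of > 36600 nM in this assay, at which 3 of the 3 values shown sit, without exception.

Compound 4 `CCOC(=O)/C=C/c1cc(/C=C/[C@](C)(/C=C/c2ccc(OC)cc2)CCC=C(C)C)ccc1O` has not yet been measured. It differs from compound 2 as follows: 2-(4-methoxyphenyl)ethenyl in place of vinyl on a saturated chain carbon bound to a double-bonded chain carbon and two saturated chain carbons with 2-(4-methoxyphenyl)ethenyl in place of vinyl on a saturated chain carbon bound to a double-bonded chain carbon and two saturated chain carbons.

Three measured steps exist: a step that the two limits leave unreadable from compound 1 to compound 2 and a step that the two limits leave unreadable from compound 1 to compound 3 and a step that the two limits leave unreadable from compound 2 to compound 3 in turn. All three exchange a group on a double-bonded chain carbon bound to a double-bonded chain carbon, so none touches the place that changes here, and none has a readable size to carry over.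

What is expected for compound 4 therefore rests on compound 2 alone, with > 36600 nM as its limit. No direction can be read from these data, and the estimated step is a number no higher from compound 2 to compound 4 (the limit leaves the size open) with no real change expected. For compound 4 the estimated value is 36600 nM with an expected range from 12000 nM to 60000 nM and a fair chance of another limit.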

Compound 4, half-maximal effective concentration: > 36600 nM
Compound 4: a limit, no number; the forecaster's own chance of this, stated with the estimate: 75%; the middle value lies on the limit itself.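

In this assay compound 4 gives > 36600 nM, which is a limit and not a number. Among the compounds shown here, compound 2 also stands only at a limit, and no step from compound 2 to compound 4 can be read. The compounds shown leave open whether 2-(4-methoxyphenyl)ethenyl in place of vinyl, or any other exchange here, changes the effect at all, with the series resting at: the limit of > 36600 nM in this assay, at which 4 of the 4 values shown sit.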